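Swapping the Ester Group of Compound 1 for Isopropyl

The compounds below may be only part of what the source reports. "The series", "measured", "known", "first", "only" and "open" are said of these compounds alone.

Of the compounds shown here, three sharing one core have been measured in an ADME assay on HEK-293T cells (Homo sapiens) for inhibition, read by luminescence, with a stated time of 72 h, tested at 5 uM; on this read-out higher numbers stand for more inhibition of growth at the one concentration tested and lower numbers for less inhibition of growth. Compound 1 `C=CS(=O)(=O)NC/C=C/c1cc(OC)cc(O)c1C(=O)OCc1ccc(Br)cc1` gives 0% in this assay. Compound 3 `COc1cc(O)c(C(=O)OCC(C)c2ccccc2)c(/C=C/CN2C(=O)C=CC2=O)c1` gives 0%, level with compound 1 at the digits shown, so the two stand together at the bottom of the three numbers. Among the compounds with values here, compound 2 `CCN(CC)C/C=C/C(=O)NC/C=C/c1cc(OCCc2ccc(F)cc2)cc(O)c1C(=O)OC(C)C` gives 28.5%, a number well beyond the scatter above compound 1, though no single-point step connects these two structures.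

Compound 4 `C=CS(=O)(=O)NC/C=C/c1cc(OC)cc(O)c1C(=O)OC(C)C` has not yet been measured. It differs from compound 1 in one place: isopropyl in place of 4-bromobenzyl on an oxygen next to a carbonyl group. Within the data shown here, no pair of measured compounds shows this change by itself, so its effect in this assay has to be estimated without a direct precedent. Because compound 1 sits at 0%, together with compound 3 at the bottom of the three numbers, the step of a number 5 percentage points higher from compound 1 to compound 4 (within the scatter) is expected to be small and within the scatter. Compound 4 is therefore estimated at 5%, with a likely range from 0% to 20%.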

Compound 4, percent growth inhibition at one concentration: 0.1%
Estimate against measurement, compound 4: 4.9 percentage points above; the measured number falls inside the stated range.
By their numbers in this assay, from the lowest: compounds 1, 3 and 4 (each within the scatter of the next); then compound 2.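

Within the data shown here, the step of a number 0.1 percentage points higher from compound 1 to compound 4 (within the scatter) is the first direct reading of this change in this assay. Taking away the 4-bromobenzyl group, with its aromatic ring and its bromine, and putting isopropyl on the same oxygen next to a carbonyl group leaves the number within the scatter, so on the core of compound 1 this change alone brings no measurable inhibition of growth. No measured information on the compounds bears on this result.

Since compound 1 and compound 4 both show almost no inhibition, the step cannot say whether the same swap would matter on a compound with a clear effect. As far as these compounds go, whether a longer alkyl chain on this oxygen, or a carboxylic acid in place of the ester, would move the number remains open.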